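Swapping a Phenyl for a Chloro on the Fused Core

The compounds below may be only part of what the source reports. "The series", "measured", "known", "first", "only" and "open" are said of these compounds alone.

Going by the values given here, compound 2 `O=C(NCCCCc1ccccc1)n1c(=O)oc2ccc(-c3ccccc3)cc21` is one of two compounds measured so far in an assay on HEK293 cells for inhibition of acid ceramidase (Homo sapiens), with a stated time of 10 min; a lower number here means a stronger inhibitor, a higher number a weaker inhibitor. In this assay compound 2 gives 42 nM, the lowest of the two numbers, while compound 1 `O=C(NCCCCc1ccccc1)n1c(=O)oc2ccccc21` gives 64 nM, a gap that lies within the scatter. Compound 3 `O=C(NCCCCc1ccccc1)n1c(=O)oc2ccc(Cl)cc21` has not yet been measured. It differs from compound 2 by chloro in place of phenyl on an aromatic carbon. Among the compounds with values here, only one measured step bears on this change: a 1.5-fold lower number from compound 1 to compound 2 (0.18 log units; within the scatter), which shows that adding a phenyl on the aromatic carbon left the number essentially where it was. Within the data shown here, no compound carrying a chloro has been measured, so the weight of the incoming group cannot be read from the data. Among the measured compounds shown here, because the one change at this carbon gave a 1.5-fold lower number from compound 1 to compound 2 (0.18 log units; within the scatter), the loss of the phenyl is expected to shift the number only slightly, and the chloro is given no separate effect. Compound 3 is therefore expected to come out at 55 nM, with a range from 20 nM to 150 nM. The expected step is a 1.3-fold higher number from compound 2 to compound 3 (0.12 log units; within the scatter), within the scatter.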

Compound 3, half-maximal inhibitory concentration: 15 nM
For compound 3 the middle estimate is 3.7-fold (0.56 log units) above the measured one; measured number below the stated range.
By their numbers in this assay, from the lowest: compound 3; then compounds 2 and 1 (each within the scatter of the next).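

In this assay, the aromatic carbon that seemed indifferent when phenyl replaced hydrogen now proves responsive to the group it carries: chloro in place of phenyl gives a 2.8-fold lower number from compound 2 to compound 3 (0.45 log units; beyond the scatter), and chloro in place of hydrogen gives a 4.3-fold lower number from compound 1 to compound 3 (0.63 log units; beyond the scatter). Both steps are modest but beyond the scatter, so this carbon is not a place where substitution leaves the number unchanged, and the single chlorine atom does what the six carbons of the phenyl did not. Nothing available explains why chloro and phenyl differ here.

The three compounds leave open whether this gain is particular to chloro or would also appear with another small group on the same carbon, such as fluoro, bromo, methyl or methoxy. They also leave open whether the step would hold if the chain shared by all three compounds were replaced by a shorter chain or a longer one, since every comparison so far rests on that one chain.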